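The compounds below may be only part of what the source reports. "The series", "measured", "known", "first", "only" and "open" are said of these compounds alone.

Among the measured compounds shown here, in a functional assay on HEK293 cells for activation of melanin-concentrating hormone receptor 1 (Homo sapiens), read by inositol phosphate accumulation (on this read-out higher numbers stand for an effect only at larger amounts of compound and lower numbers for an effect already at smaller amounts), compound 2 `CCCc1cc(N)c2cc(NC(=O)/C=C/c3ccc(F)cc3)ccc2n1` gives 200 nM, the second highest of the three numbers measured so far. Compound 1 `CC(C)(C)c1cc(N)c2cc(NC(=O)/C=C/c3ccc(C(F)(F)F)cc3)ccc2n1` gives 29 nM, and compound 3 `CCCCc1ccc(/C=C/C(=O)Nc2ccc3nc(CCC)cc(N)c3c2)cc1` gives 740 nM. Compound 4 `CCCc1cc(N)c2cc(NC(=O)/C=C/c3ccc(Cl)c(Cl)c3)ccc2n1` differs from compound 2 in one place: 3,4-dichlorophenyl in place of 4-fluorophenyl on a double-bonded chain carbon bound to a double-bonded chain carbon. For the measured compounds named here, the only measured step at the same ring, a 3.7-fold higher number from compound 2 to compound 3 (0.57 log units; beyond the scatter), shows that a change there can move the number beyond the scatter. Compound 1 differs from compound 2 in two places, so its value does not give a single step. Going by the values given here, no measured step matches the present change, so only a modest move is expected, and the change in this assay is estimated as a 1.3-fold lower number from compound 2 to compound 4 (0.12 log units; within the scatter). Compound 4 is therefore expected at 150 nM, with a range from 50 nM to 500 nM.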

Compound 4, half-maximal effective concentration: 990 nM
For compound 4 the middle estimate is 6.6-fold (0.82 log units) below the measured one, outside the stated range (above it).
By their numbers in this assay, from the lowest: compound 1; then compound 2; then compounds 3 and 4 (each within the scatter of the next).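

In this assay the move to 3,4-dichlorophenyl gives a 5.0-fold higher number from compound 2 to compound 4 (0.69 log units; beyond the scatter) and so shows that this ring position is sensitive to a halogen change as well as to butyl. Butyl gave a 3.7-fold higher number from compound 2 to compound 3 (0.57 log units; beyond the scatter) in the same direction, so both single changes from 4-fluorophenyl shown here raise the number, meaning more compound is needed for the effect. Nothing available explains the size of this rise. As far as these compounds go, whether a ring with only one chlorine would read like compound 2 or like compound 4 stays open, as does the effect of an amine or a methoxy group on this ring.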